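Swapping the oxygen substituent of a lactam-based acid amidase inhibitor

This account rests on a few compounds, and the source may have more. Where it says the series, first, only, none or still open, it means among the compounds named here.

Of the compounds shown here, two share one core and have been measured in an assay on HEK293 cells for inhibition of N-acylethanolamine-hydrolyzing acid amidase (Homo sapiens), read by fluorescence, with stated times of 10 min and 50 min; on this read-out lower numbers stand for stronger inhibition and higher numbers for weaker inhibition. Compound 1 `CCCON1C(=O)[C@@H](NC(=O)OCCCCC2CCCCC2)[C@@H]1C` gives 133 nM, while compound 2 `C[C@H]1[C@H](NC(=O)OCCCCC2CCCCC2)C(=O)N1OCCCCC1CCCCC1` gives 3470 nM. Compound 2 therefore stands at the higher, weaker end of the two numbers shown, and the single measured step, a 26-fold higher number from compound 1 to compound 2 (1.42 log units; beyond the scatter), is large and tells that the group attached to this oxygen matters greatly. Compound 3 `C[C@H]1[C@H](NC(=O)OCCCCC2CCCCC2)C(=O)N1Oc1ccc([N+](=O)[O-])cc1` differs from compound 2 at the same oxygen: 4-nitrophenyl in place of 4-cyclohexylbutyl on an oxygen. Among the measured compounds shown here, no measured pair shows an aromatic group at this place, so the only guide is that the smaller group in compound 1 gave a much lower number than compound 2. A moderate drop is therefore expected, but with wide uncertainty. In this assay, compound 3 is estimated at 500 nM, within 120 nM to 2500 nM, which would amount to the expected step of a 6.9-fold lower number from compound 2 to compound 3 (0.84 log units; beyond the scatter).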

Compound 3, half-maximal inhibitory concentration: 17 nM
The estimate for compound 3 lay 29-fold (1.47 log units) above the measured number, outside the stated range (below it).
By their numbers in this assay, from the lowest: compound 3; then compound 1; then compound 2.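

Putting an aromatic ring on this oxygen changes the picture: the step to 4-nitrophenyl is a 200-fold lower number from compound 2 to compound 3 (2.31 log units; beyond the scatter), even though the group entering has nearly as many heavy atoms as the 4-cyclohexylbutyl group it replaces. The same ring also outdoes the small propyl group, with a 7.8-fold lower number from compound 1 to compound 3 (0.89 log units; beyond the scatter), so compound 3 is the strongest inhibitor of the three and group size alone does not order these compounds. Nothing available here explains why the 4-nitrophenyl group gives this result.

The compounds shown leave open whether the gain comes from the aromatic ring itself or from the nitro group on it. A plain phenyl group or a 4-methoxyphenyl group on the same oxygen would help to separate these two possibilities.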